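A Dimethylaminophenyl Variant of Compound 2

The source may report more compounds than this note shows. Statements on the series, on what has been measured and on what is new or still open speak of the compounds shown alone.

Compound 2 `Cc1cc(O)c(C(C)C)cc1-c1cc(-c2ccco2)c(C#N)c(=O)[nH]1` gives 64% in a functional assay for inhibition, tested at 80 ug/mL; a higher number here means a stronger effect of the compound at the concentration tested, a lower number a weaker effect. Its only measured relative, compound 1 `COc1ccc(-c2cc(-c3cc(C(C)C)c(O)cc3C)[nH]c(=O)c2C#N)c(OC)c1`, gives 55% in this assay; the two lie within the scatter of each other, as the step of a number 9 percentage points higher from compound 1 to compound 2 (within the scatter) shows. Compound 3 `Cc1cc(O)c(C(C)C)cc1-c1cc(-c2ccc(N(C)C)cc2)c(C#N)c(=O)[nH]1` is not yet measured and differs from compound 2 by 4-(dimethylamino)phenyl in place of furan-2-yl on an aromatic carbon. Among the compounds with values here, the one step that exchanges a group at this same position, a number 9 percentage points higher from compound 1 to compound 2 (within the scatter), stayed within the scatter, so no step beyond the scatter is expected for compound 3 in this assay. Compound 3 is therefore estimated at 60%, between 45% and 75%, an expected step of a number 4 percentage points lower from compound 2 to compound 3 (within the scatter).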

Compound 3, a percentage reported as inhibition, at one concentration (the size of the read-out at that concentration, not a potency): 66.5%
The estimate for compound 3 lay 6.5 percentage points below the measured number; the measured number falls inside the stated range.
By their numbers in this assay, from the lowest: compounds 1, 2 and 3 (each within the scatter of the next, the first and the last beyond it).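

In this assay, replacing furan-2-yl with 4-(dimethylamino)phenyl opposite the ring nitrogen is a number 2.5 percentage points higher from compound 2 to compound 3 (within the scatter) and shows that this larger six-membered aromatic group can stand at the position without a step beyond the scatter. Within the data shown here, replacing 2,4-dimethoxyphenyl with the same group is a number 11.5 percentage points higher from compound 1 to compound 3 (beyond the scatter) and gives the first step at this position to pass the scatter. Nothing at hand explains either step. From the compounds shown here alone, what a plain phenyl or a 4-methoxyphenyl would give at this position remains open, which leaves the part played by the dimethylamino group unsettled.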